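This account rests on a few compounds, and the source may have more. Where it says the series, first, only, none or still open, it means among the compounds named here.

Measured in a functional assay on A2780 cells (Homo sapiens) for inhibition; on this read-out higher numbers stand for weaker inhibition and lower numbers for stronger inhibition:
compound 1, `CCNC(=O)c1noc(-c2cc(C(C)C)c(O)cc2O)c1-c1cc(CO)no1`, gives 5 nM
compound 2, `CCNC(=O)c1noc(-c2cc(C(C)C)c(O)cc2O)c1-c1cc(CN(CC)CC)no1`, gives 78 nM
compound 3, `CCNC(=O)c1noc(-c2cc(C(C)C)c(O)cc2O)c1-c1cc(C(=O)OCC)no1`, gives 9000 nM

Compound 3 stands highest of the three numbers, the weakest inhibitor of the set. Its nearest neighbour is compound 2 (a 120-fold higher number from compound 2 to compound 3 (2.06 log units; beyond the scatter)), the furthest compound 1 (a 1800-fold higher number from compound 1 to compound 3 (3.26 log units; beyond the scatter)); both steps into compound 3 are large and beyond the scatter, so the entry of ethoxycarbonyl on the ring coincides with the weakest inhibition seen so far.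

Compound 4, `CCCn1ccc(-c2c(C(=O)NCC)noc2-c2cc(C(C)C)c(O)cc2O)n1`, is not yet measured. The change from compound 3: 1-propyl-1H-pyrazol-3-yl in place of 3-(ethoxycarbonyl)-1,2-oxazol-5-yl on an aromatic carbon. For the measured compounds named here, the ethoxycarbonyl group leaves entirely, and the ring itself is exchanged, which no measured step covers directly. The bearing evidence is indirect: a 1800-fold higher number from compound 1 to compound 3 (3.26 log units; beyond the scatter) and a 120-fold higher number from compound 2 to compound 3 (2.06 log units; beyond the scatter) show the number climbing steeply whenever ethoxycarbonyl enters, so its removal is expected to bring the number down by a large step, about a 150-fold lower number from compound 3 to compound 4 (2.18 log units; beyond the scatter). The unprecedented ring leaves the size uncertain. Compound 4 is estimated at 60 nM, within 8 nM to 600 nM.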

Compound 4, half-maximal inhibitory concentration: 27 nM
The estimate for compound 4 lay 2.2-fold (0.35 log units) above the measured number; the range from low to high includes it.
By their numbers in this assay, from the lowest: compound 1; then compound 4; then compound 2; then compound 3.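

In this assay, the aromatic carbon next to the ring atom bearing the ethylcarbamoyl group accepts a different ring as well as different side chains: 1-propyl-1H-pyrazol-3-yl in place of 3-(ethoxycarbonyl)-1,2-oxazol-5-yl gives a 330-fold lower number from compound 3 to compound 4 (2.52 log units; beyond the scatter), so a low number here does not depend on keeping the 1,2-oxazol-5-yl ring. Against the hydroxymethyl-bearing ring, the same pyrazole gives a 5.4-fold higher number from compound 1 to compound 4 (0.73 log units; beyond the scatter), a modest step beyond the scatter, which leaves compound 1 with the lower number. No measurement available here accounts for either step.

On these data alone, since the ring and its substituent change together in both steps, their separate contributions remain open. Also open, as far as these compounds go, is how a methyl group, a longer chain or a hydroxyethyl chain in place of the propyl on the pyrazole would read in this assay.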